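The source may report more compounds than this note shows. Statements on the series, on what has been measured and on what is new or still open speak of the compounds shown alone.

Measured so far in a functional assay on KB cells (Homo sapiens) for antiproliferative activity, read by MTT assay; a higher number here means a weaker inhibitor, a lower number a stronger inhibitor:

- compound 1 `CN1CCN(c2nc(-n3ccc4ccccc43)c3ccccc3n2)CC1` gives 4.9 ug/mL as its value
- compound 2 `Cn1cc(-c2nc(N3CCNCC3)nc3ccccc23)c2ccccc21` gives 50 ug/mL as its value

Compound 2 holds the higher of these two numbers, which makes it the weaker inhibitor of the pair, and the gap down to compound 1 lies beyond the scatter. The two compounds differ in more than one place, so that gap cannot be assigned to any single change.

Compound 3 `CN1CCN(c2nc(-c3cn(C)c4ccccc34)c3ccccc3n2)CC1` departs from compound 2 in one place, piperazin-1-yl to 4-methylpiperazin-1-yl: methyl in place of hydrogen on an amine nitrogen in a ring. Among the compounds with values here, no measured step isolates this change. Within the data shown here, the only hint is that compound 1, at 4.9 ug/mL in this assay, already carries 4-methylpiperazin-1-yl. A moderate move towards a lower number is therefore expected, though it may not be large. The expected 2.5-fold lower number from compound 2 to compound 3 (0.40 log units; beyond the scatter) is a modest gain in strength. For compound 3 the estimate is 20 ug/mL in this assay, with an expected range from 6 ug/mL to 60 ug/mL around it.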

Compound 3, half-maximal inhibitory concentration: 50 ug/mL
For compound 3 the middle estimate is 2.5-fold (0.40 log units) below the measured one; low and high end bracket the measured number.
By their numbers in this assay, from the lowest: compound 1; then compounds 2 and 3 (each within the scatter of the next).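

In this assay, within the data shown here, the step of methyl in place of hydrogen on an amine nitrogen in a ring reads no change at the digits printed from compound 2 to compound 3 (within the scatter), and it is the first direct reading of this position. On the core of compound 2, the piperazine ring nitrogen three ring bonds from the ring atom that bears the large group therefore takes a methyl with no measurable consequence in this read-out, so carrying 4-methylpiperazin-1-yl, which compound 1 also has, is not enough on its own to give a lower number on this core. Nothing on hand explains why this step is flat.

What the compounds shown leave open is whether a longer chain on that same nitrogen, such as ethyl or 2-hydroxyethyl, or an acyl group such as acetyl, would shift the number on this core. They also leave open whether removing the methyl from compound 1 to give the free piperazin-1-yl would prove equally silent on the core of compound 1.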